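A few compounds are considered here, and "the series" means these few. Any claim that something is new, unique, unknown or untested is made for them only; others in the source may bear on it.

Measured so far:
Compound 1 `COC(=O)[C@H]1CC[C@@H](C(C)C)[C@@]12CC=C(C)[C@@H](O)C2`: > 500000 nM (a limit of the assay)
Compound 2 `C=C1CC[C@@]2(C(OC)[C@@H]1O)[C@@H](C(=O)O)CC[C@H]2C(C)C`: > 500000 nM (a limit of the assay)

Both readings come from an ADME assay on 3T3-L1 cells (Mus musculus) for cytotoxicity, read by luminescence and CellTiter-Glo, with a stated time of 72 h; a lower number here means that less compound is needed, a higher number that more compound is needed for the effect. Together they amount to the limit of > 500000 nM in this assay, at which 2 of the 2 values shown sit. Within the data shown here, compound 2 therefore has no exact number: its > 500000 nM is a limit, and it stands level with the only other compound tested.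

Compound 3 `C=C1CC[C@@]2(C[C@@H]1O)[C@@H](C(=O)O)CC[C@H]2C(C)C` differs from compound 2 in one place: hydrogen in place of methoxy on a saturated ring carbon. In words, this is hydrogen in place of methoxy on a saturated ring carbon, next to the ring atom that bears a hydroxy group.

Among the measured compounds shown here, no measured pair of compounds shows what this change does in this assay, so any forecast is tentative. The expectation rests on compound 2, whose > 500000 nM is a limit. No change beyond the usual scatter is expected, and no direction can be given. The step of a number no higher from compound 2 to compound 3 (the limit leaves the size open) is expected to be small. Compound 3 is estimated at 500000 nM, with an expected range of 250000 nM to 1000000 nM, and the assay may well report only a limit again.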

Compound 3, half-maximal effective concentration: > 500000 nM
Compound 3: no number, only a limit; the forecaster's own chance of this, stated with the estimate: 85%; the middle value sits exactly at the limit.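

No step can be read from compound 2 to compound 3, since neither compound has an exact number in this assay. Compound 3 joins the others at the same limit: the limit of > 500000 nM in this assay, at which 3 of the 3 values shown sit. The compounds shown leave open what concentration, if any, would produce the effect, and whether hydrogen in place of methoxy changes it.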